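Chain extension at the sulfonamide terminus

The compounds below may be only part of what the source reports. "The series", "measured", "known", "first", "only" and "open" are said of these compounds alone.

Among the measured compounds shown here, compound 3 `CC(C)(C)c1ccc(C(=O)N2CCC3(CC2)C(=O)N(CC(=O)NCNS(C)(=O)=O)CN3c2ccccc2)cc1` gives 3200 nM in an assay on HEK293 cells for displacement of a labelled ligand from NPC1-like intracellular cholesterol transporter 1 (Homo sapiens) (a lower number here means a stronger inhibitor, a higher number a weaker inhibitor), the lowest of the three numbers so far. Compound 2 `CC(C)(C)c1ccc(C(=O)N2CCC3(CC2)C(=O)N(CC(=O)NCCN)CN3c2ccccc2)cc1` gives 7000 nM and compound 1 `CC(C)(C)OC(=O)NCCCCCNC(=O)CN1CN(c2ccccc2)C2(CCN(C(=O)c3ccc(C(C)(C)C)cc3)CC2)C1=O` gives 13700 nM in this assay. The measured steps were a 4.3-fold lower number from compound 1 to compound 3 (0.63 log units; beyond the scatter) and a 2.2-fold lower number from compound 2 to compound 3 (0.34 log units; beyond the scatter), while a 2.0-fold lower number from compound 1 to compound 2 (0.29 log units; within the scatter). Compound 4 `CC(C)(C)c1ccc(C(=O)N2CCC3(CC2)C(=O)N(CC(=O)NCCCNS(C)(=O)=O)CN3c2ccccc2)cc1` differs from compound 3 by 2-(methanesulfonamido)ethyl in place of methanesulfonamido on a saturated chain carbon bound to an amide-type nitrogen. For the measured compounds named here, no measured step lengthens the chain while keeping the terminal group fixed; the steps that changed the terminus were modest, and the one step that mainly altered chain length stayed within the scatter. A step of a 1.1-fold lower number from compound 3 to compound 4 (0.03 log units; within the scatter) is therefore expected, with nothing beyond the scatter. Compound 4 is estimated at 3000 nM, within 1200 nM to 8000 nM.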

Compound 4, half-maximal inhibitory concentration: 10400 nM
Compound 4: the middle estimate sits 3.5-fold (0.54 log units) below what was measured; measured number above the stated range.
By their numbers in this assay, from the lowest: compound 3; then compounds 2, 4 and 1 (each within the scatter of the next).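

In this assay, chain length at the sulfonamide terminus matters at this position: with methanesulfonamido kept as the terminal group, 2-(methanesulfonamido)ethyl in place of methanesulfonamido gives a 3.3-fold higher number from compound 3 to compound 4 (0.51 log units; beyond the scatter). The sulfonamide alone therefore does not set the result, since the steps to the other terminal groups, a 1.5-fold higher number from compound 2 to compound 4 (0.17 log units; within the scatter) and a 1.3-fold lower number from compound 1 to compound 4 (0.12 log units; within the scatter), both stay within the scatter. Among these compounds, only the shorter chain of compound 3 stands apart from compound 4.

Still open, on these data alone, is how a longer chain ending in methanesulfonamido, or a carboxylic acid at the chain end, would read here. Nothing available bears on why the two chain lengths differ.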